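The source may report more compounds than this note shows. Statements on the series, on what has been measured and on what is new or still open speak of the compounds shown alone.

Measured so far:
compound 1, `O=C1N=C(O)S/C1=C\c1ccc(OCCc2ccsc2)cc1`, 60 nM
compound 2, `O=C1N=C(O)S/C1=C\c1ccc(OCCc2ccccn2)cc1`, 660 nM

Both were tested in an assay for inhibition of 15-hydroxyprostaglandin dehydrogenase [NAD(+)] (Homo sapiens), read by fluorescence and spectrophotometry; on this read-out higher numbers stand for weaker inhibition and lower numbers for stronger inhibition. Within the data shown here, compound 2 stands highest of the two numbers; the only measured step, an 11-fold higher number from compound 1 to compound 2 (1.04 log units; beyond the scatter), separates it from compound 1, and it is a large one, beyond the scatter.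

Compound 3, `CC1CCC(COc2ccc(/C=C3\SC(O)=NC3=O)cc2)CC1`, is the next candidate. The change is 4-methylcyclohexyl in place of (pyridin-2-yl)methyl on a saturated chain carbon bound to an oxygen on an aromatic ring. Among the measured compounds shown here, the one step measured so far bears on it only loosely: it shows that exchanging the ring at the end of the chain can shift this assay by a large amount, but it does not involve a ring of carbon only nor a ring placed directly on the chain carbon. Since compound 2 sits well above compound 1, the expected step of a 4.4-fold lower number from compound 2 to compound 3 (0.64 log units; beyond the scatter) is downward, of moderate size, with wide uncertainty. Compound 3 is estimated at 150 nM, within 30 nM to 700 nM.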

Compound 3, half-maximal inhibitory concentration: 52 nM
The estimate for compound 3 lay 2.9-fold (0.46 log units) above the measured number, and the stated range covers the measured number.
By their numbers in this assay, from the lowest: compounds 3 and 1 (each within the scatter of the next); then compound 2.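

Against (pyridin-2-yl)methyl, the 4-methylcyclohexyl group gives a 13-fold lower number from compound 2 to compound 3 (1.10 log units; beyond the scatter) in this assay, while against (thiophen-3-yl)methyl it gives a 1.2-fold lower number from compound 1 to compound 3 (0.06 log units; within the scatter), a difference within the scatter, so compound 1 and compound 3 cannot be ranked. Among these three compounds, then, an aromatic ring at this place is not needed for a low number: a non-aromatic ring of carbon only does as well as the thiophene-bearing group, and only compound 2 stands apart. No measurement is available to explain these differences.

As far as these compounds go, whether the methyl group on the cyclohexyl ring matters remains open, as does how a plain cyclohexyl or a phenyl group would compare. It is also unknown what an amine or a carboxylic acid on this ring would do in this assay.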